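A Chloro for Fluoro Swap in a Flat Series

The compounds below may be only part of what the source reports. "The series", "measured", "known", "first", "only" and "open" are said of these compounds alone.

In a functional assay, read by spectrophotometry, tested at 100 uM (a lower number here means a stronger inhibitor, a higher number a weaker inhibitor), compound 1 `O=C(/C=C/c1ccccc1)c1cccc(NC(=O)c2cc(-c3ccncc3)n[nH]2)c1` gives 71500 nM, compound 2 `O=C(/C=C/c1cccc2ccccc12)c1cccc(NC(=O)c2cc(-c3ccncc3)n[nH]2)c1` gives 72100 nM and compound 3 `O=C(/C=C/c1ccc(F)cc1)c1cccc(NC(=O)c2cc(-c3ccncc3)n[nH]2)c1` gives 58700 nM. Compound 3 thus stands within the scatter of both others. Compound 4 `O=C(/C=C/c1ccc(Cl)cc1)c1cccc(NC(=O)c2cc(-c3ccncc3)n[nH]2)c1` differs from it at one place chloro in place of fluoro on an aromatic carbon, para to a large group. For the measured compounds named here, two measured steps bear on this. Fluoro in place of hydrogen on an aromatic carbon gave a 1.2-fold lower number from compound 1 to compound 3 (0.09 log units; within the scatter), and naphthalen-1-yl in place of phenyl gave a 1.0-fold higher number from compound 1 to compound 2 (0.00 log units; within the scatter). Neither leaves the scatter, so no change beyond it is expected. The estimated step is a 1.0-fold higher number from compound 3 to compound 4 (0.01 log units; within the scatter). Compound 4 is expected at 60000 nM, with an estimated range of 35000 nM to 100000 nM.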

Compound 4, half-maximal inhibitory concentration: 78900 nM
Estimate against measurement, compound 4: 1.3-fold (0.12 log units) below; the range from low to high includes it.
By their numbers in this assay, from the lowest: compounds 3, 1, 2 and 4 (each within the scatter of the next).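

In this assay, chloro in place of fluoro on an aromatic carbon, para to a large group, gives no change beyond the scatter (a 1.3-fold higher number from compound 3 to compound 4 (0.13 log units; within the scatter)), so a second halogen at this position reads the same as the first. Against the other two compounds the picture is equally flat, with chloro in place of hydrogen (a 1.1-fold higher number from compound 1 to compound 4 (0.04 log units; within the scatter)) and 4-chlorophenyl in place of naphthalen-1-yl (a 1.1-fold higher number from compound 2 to compound 4 (0.04 log units; within the scatter)). No measurement at hand accounts for this flatness. From the compounds shown here alone, whether a methoxy group, an amine or a carboxylic acid at this position would move the number beyond the scatter remains open.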